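This account rests on a few compounds, and the source may have more. Where it says the series, first, only, none or still open, it means among the compounds named here.

Measured so far:

compound 1, `COc1ncnc2c1c(-c1ccccc1)cn2[C@@H]1O[C@H](CO)[C@@H](O)[C@H]1O`, > 20000 nM
compound 2, `CNc1ncnc2c1c(-c1ccccc1)cn2[C@@H]1O[C@H](CO)[C@@H](O)[C@H]1O`, > 20000 nM
compound 3, `O=c1[nH]cnc2c1c(-c1cc3ccccc3o1)cn2[C@@H]1O[C@H](CO)[C@@H](O)[C@H]1O`, > 20000 nM

In a functional assay on CEM-DNR-bulk cells (Homo sapiens), read by MTT assay, with a stated time of 72 h (a lower number here means a stronger inhibitor, a higher number a weaker inhibitor), compound 1 gives only a limit of the assay, > 20000 nM. Compound 2 likewise gives only a limit in this assay, > 20000 nM. Compound 3 also gives only a limit, > 20000 nM. So compound 2 stands where every measured value stands: at the limit of > 20000 nM in this assay, at which 3 of the 3 values shown sit, with no number of its own. Within the data shown here, the only measured step between neighbouring compounds, a step that the two limits leave unreadable from compound 1 to compound 2, cannot be read for size because both of its ends are limits.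

Compound 4, `CNc1ncnc2c1c(-c1ccoc1)cn2[C@@H]1O[C@H](CO)[C@@H](O)[C@H]1O`, differs from compound 2 in one place: furan-3-yl in place of phenyl on an aromatic carbon. No measured step touches this group on the shared core, so nothing shown tells how such a swap moves the value. With all three measured compounds sitting at the limit, the expectation for compound 4 is that it also sits at or past that limit, with an expected step that the limit leaves unreadable from compound 2 to compound 4 of no readable size. Compound 4 is therefore estimated at 40000 nM, within 10000 nM to 150000 nM.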

Compound 4, half-maximal inhibitory concentration: > 20000 nM
Compound 4: a limit, no number; the forecaster's own chance of this, stated with the estimate: 85%; the middle value lies beyond the limit too.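

Among these compounds, compound 2 and compound 4 both give only a limit, so swapping phenyl for furan-3-yl yields no step that can be read. The compounds shown leave open whether any change on the shared core would give an actual number in this assay, since all of them stand at one point: the limit of > 20000 nM in this assay, at which 4 of the 4 values shown sit.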